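A few compounds are considered here, and "the series" means these few. Any claim that something is new, unique, unknown or untested is made for them only; others in the source may bear on it.

Measured compounds:
compound 1 `c1ccc(OCc2cn(C(c3ccccc3)c3ccccc3)nn2)cc1`: 31300 nM
compound 2 `Clc1ccc(OCc2cn(C(c3ccccc3)c3ccccc3)nn2)cc1`: 13400 nM
compound 3 `N#Cc1ccc(Cn2cc(COc3ccccc3)nn2)cc1`: 6090 nM

All three numbers come from an assay on isolated protein for inhibition of Aromatase (Homo sapiens), read by fluorescence and colorimetric assay, with a stated time of 30 min; a lower number here means a stronger inhibitor, a higher number a weaker inhibitor. Compound 1 and compound 2 share one core and differ by chloro in place of hydrogen on an aromatic carbon; this gave a 2.3-fold lower number from compound 1 to compound 2 (0.37 log units; beyond the scatter). Compound 3 rests on another core, and the difference between the two cores is not broken down here. Among the three, compound 3 has the lowest number.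

Compound 4 `N#Cc1ccc(Cn2cc(COc3ccc(Cl)cc3)nn2)cc1` is not yet measured in this assay. It differs from compound 3 by chloro in place of hydrogen on an aromatic carbon, the same change as between compound 1 and compound 2, at a place described in the same words. A step of a 2.3-fold lower number from compound 3 to compound 4 (0.35 log units; beyond the scatter) is expected because a 2.3-fold lower number from compound 1 to compound 2 (0.37 log units; beyond the scatter) was seen for the same change. For compound 4 the estimated value is 2700 nM, expected to lie between 1200 nM and 6000 nM.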

Compound 4, half-maximal inhibitory concentration: 3910 nM
Beside the measured number, compound 4's estimate is 1.4-fold (0.16 log units) below it, and the stated range covers the measured number.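

In this assay, going from phenyl to 4-chlorophenyl on the core of compound 3 gives a 1.6-fold lower number from compound 3 to compound 4 (0.19 log units; within the scatter), so this step alone does not separate the two compounds. Set beside the earlier step, the change reads alike on both cores: the same change on two cores in this assay, a 2.3-fold lower number (0.37 log units; beyond the scatter) from compound 1 to compound 2 and a 1.6-fold lower number (0.19 log units; within the scatter) from compound 3 to compound 4, 1.5-fold (0.18 log units) apart, within the scatter of two such steps. This shows no measurable difference between these two cores for this one change, but two pairs, one of them within the scatter, do not fix the size of the step or show that it holds on any further core.

From the compounds shown here alone, it remains open what a methoxy group, an amine or a carboxylic acid would give in place of chloro. The part played by the nitrile also stays open, as no pair shown differs only there.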